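The source may hold more compounds than are shown below. What is called first, only, known or untested is meant among the compounds shown, and "the series" means these compounds.

Compound 2 `CC1CC(C)CN(c2nc(C(F)(F)Cl)ccc2CNC(=O)C(C)c2ccc(NS(C)(=O)=O)c(F)c2)C1` was tested in an assay on CHO cells for antagonist activity at transient receptor potential cation channel subfamily V member 1 (Homo sapiens), read by FLIPR (on this read-out higher numbers stand for weaker inhibition and lower numbers for stronger inhibition), where compound 2 gives 1 nM. Compound 1 `CC(C(=O)NCc1ccc(C2CC2)nc1N1CCCCC1)c1ccc(NS(C)(=O)=O)c(F)c1` gives 1.1 nM in this assay, so the two numbers fall within the usual scatter of each other and cannot be told apart. Compound 3 `CC(C(=O)NCc1ccc(C(F)(F)Cl)nc1OC1CCCCC1)c1ccc(NS(C)(=O)=O)c(F)c1` has not yet been measured. It differs from compound 2 by cyclohexyloxy in place of 3,5-dimethylpiperidin-1-yl on an aromatic carbon. Going by the values given here, no measured pair shows this kind of change, so the direction is uncertain; a modest step toward weaker inhibition, a 3.0-fold higher number from compound 2 to compound 3 (0.48 log units; beyond the scatter), is expected. For compound 3 the estimated value in this assay is 3 nM, within a range from 0.8 nM to 15 nM.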

Compound 3, inhibition constant: 0.9 nM
Estimate against measurement, compound 3: 3.3-fold (0.52 log units) above; the measured number falls inside the stated range.
By their numbers in this assay, from the lowest: compounds 3, 2 and 1 (each within the scatter of the next).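

In this assay, cyclohexyloxy in place of 3,5-dimethylpiperidin-1-yl gives a 1.1-fold lower number from compound 2 to compound 3 (0.05 log units; within the scatter) and so leaves the reading unchanged within the scatter. At this aromatic carbon, then, a carbon-only ring joined through oxygen and a dimethylated nitrogen ring cannot be told apart, at least with the chloro(difluoro)methyl group in place. No measurement shown explains why the two groups read alike.

The compounds shown leave open how an open butoxy chain or a small amine such as dimethylamino would read at this position. They also leave open whether cyclohexyloxy would match 3,5-dimethylpiperidin-1-yl with a different neighbouring group on the ring, such as cyclopropyl.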